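This account rests on a few compounds, and the source may have more. Where it says the series, first, only, none or still open, it means among the compounds named here.

Compound 1, `CCCc1nc2c(C)cc(-c3nc4ccccc4n3C)cc2n1S(=O)(=O)c1ccc(C)cc1`: > 50000 nM.
Compound 2, `CCCc1nc2c(C)cc(-c3nc4ccccc4n3C)cc2n1S(=O)(=O)c1ccc(OC)cc1`: 34700 nM.

For compound 1 the result in a functional assay on A549 cells (Homo sapiens) for cytotoxicity, read by MTT assay (on this read-out higher numbers stand for weaker inhibition and lower numbers for stronger inhibition), is a limit of the assay, > 50000 nM. Going by the values given here, compound 2 is the only compound with a number in this assay, where it gives 34700 nM. Compound 3, `CCCc1nc2c(C)cc(-c3nc4ccccc4n3C)cc2n1S(=O)(=O)c1ccc(Cl)cc1`, is not yet measured. It differs from compound 2 by chloro in place of methoxy on an aromatic carbon. Among the compounds with values here, only one measured step bears on this position: an at least 1.4-fold lower number from compound 1 to compound 2 (0.15 log units; that floor lies within the scatter), a step whose floor lies within the scatter, and its size is uncertain because of the limit of > 50000 nM in this assay, at which 1 of the 2 values shown sits. A second change at the same carbon, swapping one small group for another, is therefore not expected to move the number beyond the scatter. For compound 3 the step is expected to be a 1.2-fold higher number from compound 2 to compound 3 (0.06 log units; within the scatter). Compound 3 is thus estimated at 40000 nM, within 15000 nM to 100000 nM, with a fair chance that only a limit is reported.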

Compound 3, half-maximal inhibitory concentration: > 50000 nM
Compound 3 was reported as a limit (the forecaster's own chance of this, stated with the estimate: 40%); middle value at least 1.2-fold (0.09 log units) away from the limit.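

With compound 3, a second group at this aromatic carbon ends at a limit in this assay. Going from 4-methoxyphenyl to 4-chlorophenyl gives an at least 1.4-fold higher number from compound 2 to compound 3 (0.15 log units; that floor lies within the scatter), so the change has a floor but no readable size. Compound 3 joins compound 1 at a limit, which leaves the step between them unreadable and compound 2 as the only compound with a number, and no step at this position is yet shown to lie beyond the scatter: the limit of > 50000 nM in this assay, at which 2 of the 3 values shown sit.

On these data alone, what an amine or a carboxylic acid on this aromatic carbon would give in this assay remains open, as does whether any group here can move the number beyond the scatter. Also open, as far as these compounds go, is how far the true numbers of compound 1 and compound 3 lie from their limits.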